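Swapping hydrogen for acetoxy: what to expect

This account rests on a few compounds, and the source may have more. Where it says the series, first, only, none or still open, it means among the compounds named here.

Compound 1 `CSc1ccc(/C=C/C=C/C(=O)N2CCCCC2)cc1` gives 11.8% in an assay for inhibition of Polyunsaturated fatty acid 5-lipoxygenase (Homo sapiens), read by spectrophotometry, tested at 20 uM; a lower number here means less inhibition, a higher number more inhibition at the concentration tested (going by the name of the read-out). Compound 2 `O=C(/C=C/C=C/c1ccccc1)N1CCCCC1` gives 36.3%.

For the measured compounds named here, compound 2 stands highest of the two numbers measured so far; the step of a number 24.5 percentage points higher from compound 1 to compound 2 (beyond the scatter) separates it from compound 1. Compound 3 `CC(=O)Oc1ccc(/C=C/C=C/C(=O)N2CCCCC2)cc1` differs from compound 2 by acetoxy in place of hydrogen on an aromatic carbon. Going by the values given here, only one measured step bears on this change: a number 24.5 percentage points higher from compound 1 to compound 2 (beyond the scatter) shows that removing methylsulfanyl from that same aromatic carbon raised inhibition, so placing a group there again, now acetoxy, is expected to lower it by a number 14.3 percentage points lower from compound 2 to compound 3 (beyond the scatter). Compound 3 is therefore estimated at 22%, with a range from 5% to 45%.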

Compound 3, a percentage reported as inhibition, at one concentration (the size of the read-out at that concentration, not a potency): 18.3%
Compound 3: the middle estimate sits 3.7 percentage points above what was measured, within the range that was stated.
By their numbers in this assay, from the lowest: compounds 1 and 3 (each within the scatter of the next); then compound 2.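

Acetoxy on this aromatic carbon, para to a large group, gives a number 18 percentage points lower from compound 2 to compound 3 (beyond the scatter) in this assay, so a second, quite different group also goes with less inhibition than hydrogen. Acetoxy in place of methylsulfanyl gives a number 6.5 percentage points higher from compound 1 to compound 3 (within the scatter) and so does not separate these two groups. Nothing available explains why either group goes with the lower number.

On these data alone, whether this holds for other groups stays open: an amine, a hydroxyl or a fluorine on the same carbon could fall with these two or stay close to hydrogen.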